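Shortening the Butyl Chain: Expected Cytotoxicity of Compound 4

The source may report more compounds than this note shows. Statements on the series, on what has been measured and on what is new or still open speak of the compounds shown alone.

Of the compounds shown here, three sharing one core have been tested in an ADME assay on RAW264.7 cells (Mus musculus) for cytotoxicity, read by MTT assay, with a stated time of 18 h; a higher number here means that more compound is tolerated, a lower number that less compound is tolerated. Compound 1 `C=C1C(=O)OC[C@H]1CCOC(=O)Nc1ccc(C(=O)OCCCC)cc1` gives 8940 nM. Compound 2 `C=C1C(=O)OC[C@@H]1CCOC(=O)Nc1ccc(CCCC)cc1` gives 9950 nM. Compound 3 `C=C1C(=O)OC[C@H]1CCOC(=O)Nc1ccc(CCCC)cc1` gives 15900 nM. Compound 2 holds the second highest of the three numbers, yet all three lie within the scatter of one another. The step of a 1.8-fold higher number from compound 1 to compound 3 (0.25 log units; within the scatter) and the step of a 1.6-fold higher number from compound 2 to compound 3 (0.20 log units; within the scatter) both stay within the scatter; the latter is worth noting because of the fact that compounds 2 and 3 differ only in the configuration as drawn.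

Compound 4 `C=C1C(=O)OC[C@@H]1CCOC(=O)Nc1ccc(CC)cc1` has not yet been measured. It differs from compound 2 by hydrogen in place of ethyl on a saturated chain carbon, two bonds along the chain from an aromatic carbon. Going by the values given here, no measured step shortens the chain in this way; the nearest comparison is the swap of butoxycarbonyl for butyl in a 1.8-fold higher number from compound 1 to compound 3 (0.25 log units; within the scatter), which left the number within the scatter. Compound 4 is therefore expected to give 11000 nM in this assay, with a range from 5000 nM to 25000 nM. The step this implies, a 1.1-fold higher number from compound 2 to compound 4 (0.04 log units; within the scatter), is expected to stay within the scatter.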

Compound 4, half-maximal cytotoxic concentration: 7580 nM
Beside the measured number, compound 4's estimate is 1.5-fold (0.16 log units) above it; low and high end bracket the measured number.
By their numbers in this assay, from the lowest: compounds 4, 1, 2 and 3 (each within the scatter of the next, the first and the last beyond it).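

In this assay, going by these compounds alone, this is the first step that changes the length of the chain itself, as butyl becomes ethyl: a 1.3-fold lower number from compound 2 to compound 4 (0.12 log units; within the scatter). The earlier steps shown here changed only the butoxycarbonyl group or the drawn configuration, so this adds that, in the configuration of compound 2, the shorter chain cannot be told apart from butyl by this read-out. Within the data shown here, nothing available explains this result, and with only a single step in chain length, no trend can be drawn from it.

The compounds shown leave open whether a longer chain such as hexyl, or an amine or a carboxylic acid in place of butyl, would also stay within the scatter. They also leave open whether ethyl in the opposite drawn configuration would match compound 4.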